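The source may hold more compounds than are shown below. What is called first, only, known or untested is meant among the compounds shown, and "the series" means these compounds.

Of the compounds shown here, three of one family have been tested, and a fourth awaits testing. Compound 1 `CC(C(=O)N1CCN(c2ccccc2F)CC1)N1C(=O)CCC1=O` and compound 2 `CCC(C(=O)N1CCN(c2ccccc2F)CC1)N1C(=O)CCC1=O` share a core. Compound 3 `CCC(C(=O)N1CCN(c2cccc(C(F)(F)F)c2)CC1)N1C(=O)CCC1=O` carries a different ring at one end of that core; how the two cores differ is not broken down here. Compound 4 `CC(C(=O)N1CCN(c2cccc(C(F)(F)F)c2)CC1)N1C(=O)CCC1=O` is the member not yet measured.

The read-out is a functional assay on the whole organism (strain Swiss) with Mus musculus as the target, in the maximal electroshock model, with a stated time of 2 h, at a dose of 100 mg/kg by the intraperitoneal route; a higher number here means a stronger effect of the compound at the dose given, a lower number a weaker effect. In this assay compound 1 gives 0%, compound 2 gives 0% and compound 3 gives 0%. All three read-outs lie within the scatter of one another, so none of the three can be set apart from the others at this dose.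

Between compound 2 and compound 1 stands one structural difference, (hydrogen in place of methyl on a saturated chain carbon, two bonds along the chain from an amide-type nitrogen in a ring and a carbonyl carbon). The step that goes with it is no change at the digits printed from compound 2 to compound 1 (within the scatter). Compound 4 differs from compound 3 by hydrogen in place of methyl on a saturated chain carbon, two bonds along the chain from an amide-type nitrogen in a ring and a carbonyl carbon, the same change, made this time on the core of compound 3.

A step of about the same size is expected in this assay, namely no change at the digits printed from compound 3 to compound 4 (within the scatter), because no change at the digits printed from compound 2 to compound 1 (within the scatter) and because compound 3 gives 0%. Compound 4 is therefore expected to give 0%, with a range from 0% to 15%. The expectation rests on a single measured instance of the change and on three compounds that all sit at the bottom of the scale, which is a narrow base.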

Compound 4, a percentage reported as activity, at one dose (the size of the read-out at that dose, not a potency): 0%
Estimate against measurement, compound 4: no gap at the digits printed; low and high end bracket the measured number.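

In this assay, trading ethyl for methyl on the core of compound 3, which puts hydrogen in place of methyl on a saturated chain carbon, gives no change at the digits printed from compound 3 to compound 4 (within the scatter). Set beside the earlier instance of this change, the two steps agree: the same change on two cores in this assay, no change at the digits printed (within the scatter) from compound 2 to compound 1 and no change at the digits printed (within the scatter) from compound 3 to compound 4, 0 percentage points apart, within the scatter of two such steps

This shows that on both cores the change leaves the read-out where it was, but all four compounds sit at the very bottom of the scale at a single dose, and a step measured there has no room to go lower and says little about what the change does to a compound with a visible effect. The agreement is therefore one between two flat results, and it does not show that the change would be neutral on a core that is active in this assay.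

The compounds shown leave open whether any member of this family gives a read-out above the bottom of the scale, for instance with a longer chain such as propyl or benzyl at that carbon. They also leave open what a chlorine, a methoxy group or an amine on the aromatic ring would do, and how the family behaves at other doses or times.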